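A few compounds are considered here, and "the series" means these few. Any claim that something is new, unique, unknown or untested is made for them only; others in the source may bear on it.

Measured so far in an assay on isolated protein for inhibition of protein kinase C theta type (Homo sapiens), read by TR-FRET, with a stated time of 2 h; on this read-out higher numbers stand for weaker inhibition and lower numbers for stronger inhibition:
compound 1 `N#Cc1cnc(NCc2cnccc2C(F)(F)F)cc1NC[C@H]1CC[C@H](O)CC1` gives 50 nM;
compound 2 `N#Cc1cnc(NCc2cnccc2C(F)(F)F)cc1N[C@H]1CC[C@@H](n2cncn2)CC1` gives 100 nM;
compound 3 `CC(C)(C)Oc1ncncc1CNc1cc(N[C@H]2CC[C@@H](O)CC2)c(C#N)cn1` gives 200 nM.

Compound 1 returns the lowest of the three numbers in this assay, but its gap to compound 2 lies within the usual scatter, so no order can be read between those two; compound 3 stands above compound 1 by a gap beyond the scatter. Compound 4 `CC1(C)C[C@@H](Nc2cc(NCc3cnccc3C(F)(F)F)ncc2C#N)CC[C@H]1O` has not yet been measured. It differs from compound 1 in a single place: 4-hydroxy-3,3-dimethylcyclohexyl in place of (4-hydroxycyclohexyl)methyl on a nitrogen on an aromatic ring. For the measured compounds named here, no step between measured compounds that differ in only one place is available, so any expectation rests on the three numbers alone and on this change. Compound 2 and compound 3, which differ from compound 1 in other ways, both give higher numbers than compound 1, though compound 2 only within the scatter, and this offers no more than a loose hint about compound 4. The expected step is small, toward a higher number, and may well stay within the scatter: a 2.0-fold higher number from compound 1 to compound 4 (0.30 log units; within the scatter). Compound 4 is therefore estimated at 100 nM in this assay, with a range from 40 nM to 300 nM.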

Compound 4, half-maximal inhibitory concentration: 120 nM
Compound 4: the middle estimate sits 1.2-fold (0.08 log units) below what was measured; the measured number falls inside the stated range.
By their numbers in this assay, from the lowest: compounds 1, 2, 4 and 3 (each within the scatter of the next, the first and the last beyond it).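

For the compounds shown here, the change from (4-hydroxycyclohexyl)methyl to 4-hydroxy-3,3-dimethylcyclohexyl on a nitrogen on an aromatic ring gives, in this assay, a 2.4-fold higher number from compound 1 to compound 4 (0.38 log units; beyond the scatter) and is the first one-place comparison in this set, showing that the number responds modestly but beyond the scatter to what sits at this position. The step is not a large one, even though the entering group differs in how its ring is attached and in its added dimethyl pair, while it keeps the one six-membered carbon ring and the same counts of hydrogen-bond donors and acceptors as the group it replaces. Nothing available here explains why the number rises with this change.

The single step joins the altered attachment and the dimethyl pair, so the compounds shown leave open how much of the rise belongs to each, which the undecorated 4-hydroxycyclohexyl group on the core of compound 1 could separate. They also leave open whether the hydroxyl itself matters at this position, as an amine or a carboxylic acid in its place, or a longer chain to the ring, would test.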